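The compounds below may be only part of what the source reports. "The series", "measured", "known", "first", "only" and "open" are said of these compounds alone.

Compound 3 `O/N=C(/CSc1nnc(-c2ccccc2)n1-c1ccccc1)c1ccccc1` gives 63% in a functional assay on the whole organism (strain albino) for inhibition, with Rattus norvegicus as the target, read by paw edema, with a stated time of 2 h, at a dose of 0.28 mmol/kg by the oral route; on this read-out lower numbers stand for less inhibition and higher numbers for more inhibition at the one dose given (going by the name of the read-out). Compound 1 `COc1ccc(-c2nnc(SC/C(=N/O)c3ccccc3)n2-c2ccccc2)cc1` gives 63% in this assay, so the two stand level at the digits shown, and compound 2 `COc1ccc(-c2nnc(SCC(=O)c3ccccc3)n2-c2ccccc2)cc1OC` with 57% lies within the scatter of both. Among the compounds with values here, the one single-point step in the set, no change at the digits printed from compound 1 to compound 3 (within the scatter), is the one that bears on the change now at hand.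

Compound 4 `COc1ccc(-c2nnc(SC/C(=N/O)c3ccccc3)n2-c2ccccc2)cc1OC` differs from compound 3 in one place: 3,4-dimethoxyphenyl in place of phenyl on an aromatic carbon. Compound 2 carries the same entering group but also a carbonyl in place of the oxime, so its value speaks only loosely here. Given that adding or removing a methoxy gave no change at the digits printed from compound 1 to compound 3 (within the scatter), the step of a number 3 percentage points lower from compound 3 to compound 4 (within the scatter) is expected to stay within the scatter. Compound 4 is therefore estimated at 60%, with a range of 48% to 72%.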

Compound 4, a percentage reported as inhibition, in the whole organism at one dose (the size of the read-out at that dose, not a potency): 61%
For compound 4 the middle estimate is 1 percentage points below the measured one, within the range that was stated.
By their numbers in this assay, from the lowest: compounds 2, 4, 1 and 3 (each within the scatter of the next).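

In this assay the change to 3,4-dimethoxyphenyl on this aromatic carbon gives a number 2 percentage points lower from compound 3 to compound 4 (within the scatter) and the added methoxy alone gives a number 2 percentage points lower from compound 1 to compound 4 (within the scatter) so compound 1, compound 3 and compound 4 cannot be told apart at this position. With 3,4-dimethoxyphenyl in place, the oxime-bearing group in place of the carbonyl-bearing one gives a number 4 percentage points higher from compound 2 to compound 4 (within the scatter) so this change cannot be read as an effect either. Nothing available explains why these changes leave the read-out within the scatter.

On these data alone, whether an amine or a carboxylic acid on this phenyl group, or a longer chain on the sulfur, would move the number beyond the scatter stays open.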